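Removing the benzamido of compound 1 for tert-butyl

The source may report more compounds than this note shows. Statements on the series, on what has been measured and on what is new or still open speak of the compounds shown alone.

Measured so far:
compound 1 `Nc1ncccc1-c1nc2cccnc2n1-c1ccc(NC(=O)c2ccccc2)cc1` gives 14 nM in an in vitro assay on Sf9 cells for inhibition of RAC-alpha serine/threonine-protein kinase (Homo sapiens), read by AlphaScreen, with a stated time of 20 min; a lower number here means a stronger inhibitor, a higher number a weaker inhibitor;
compound 2 `Nc1ncccc1-c1nc2cc(-c3cccnc3)cnc2n1-c1ccc(CNC(=O)c2ccccc2)cc1` gives 8 nM in this assay.

Compound 1 has the higher of the two numbers, and compound 2 sits within the scatter of it. Compound 3 `CC(C)(C)c1ccc(-n2c(-c3cccnc3N)nc3cccnc32)cc1` differs from compound 1 in one place: tert-butyl in place of benzamido on an aromatic carbon. For the measured compounds named here, no measured pair shows this change, so its size is unknown; a loss of potency beyond the scatter is expected here, since the group that leaves is large and the group that enters is small. Compound 3 is therefore estimated at 100 nM, between 25 nM and 500 nM, a step of a 7.1-fold higher number from compound 1 to compound 3 (0.85 log units; beyond the scatter).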

Compound 3, half-maximal inhibitory concentration: 3900 nM
Compound 3: middle estimate off by 39-fold (1.59 log units), on the low side; measured number above the stated range.
By their numbers in this assay, from the lowest: compounds 2 and 1 (each within the scatter of the next); then compound 3.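

In this assay, putting tert-butyl in place of benzamido on this aromatic carbon gives a 280-fold higher number from compound 1 to compound 3 (2.44 log units; beyond the scatter). This is the first one-place change shown at this position, and it shows that potency depends strongly on the group held there. No measurement shown here explains the size of this step. From the compounds shown here alone, the change removes the ring, the carbonyl and the amide hydrogen together, so it remains open which of these parts matters. An acetamido group or a simple amine at this position would help separate them.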